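The compounds below may be only part of what the source reports. "The series", "measured", "known", "first", "only" and "open" are said of these compounds alone.

The account begins with compound 1, `c1ccc(-c2nc3ccc(N4CCCCC4)nc3o2)cc1`, which in an assay on isolated protein for inhibition of Amine oxidase [flavin-containing] B (Homo sapiens), read by fluorescence, with a stated time of 1 h, tested at 10 uM (on this read-out higher numbers stand for more inhibition at the one concentration tested (going by the name of the read-out) and lower numbers for less inhibition), gives 86.8%. Compound 2, `Fc1ccccc1-c1nc2ccc(N3CCCCC3)nc2o1`, differs from compound 1 by fluoro in place of hydrogen on an aromatic carbon; in this assay compound 2 gives 94.9%, and the step of a number 8.1 percentage points higher from compound 1 to compound 2 (within the scatter) is within the scatter. Compound 3, `c1ccc(-c2nc3ccc(N4CCCCC4)nc3s2)cc1`, carries a different core; the difference between the two cores is not broken down here. In this assay compound 3 gives 95.5%, which stands within the scatter of compound 2 and of compound 1, so no order among the three is claimed.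

Compound 4, `Fc1ccc(-c2nc3ccc(N4CCCCC4)nc3s2)cc1`, is not yet measured. It differs from compound 3 by fluoro in place of hydrogen on an aromatic carbon. This is the same kind of change as that from compound 1 to compound 2, but the place is not the same: in compound 2 the fluoro sits ortho to a large group, in compound 4 it sits para to a large group. On the core of compound 3 the change has not been tested. The expectation for compound 4 rests on compound 3 because its value of 95.5% already lies high, and on the earlier pair because the same kind of change gave a number 8.1 percentage points higher from compound 1 to compound 2 (within the scatter). Compound 4 is therefore expected to give 95%, most likely between 87% and 99%. That expectation corresponds to an estimated step of a number 0.5 percentage points lower from compound 3 to compound 4 (within the scatter), within the scatter.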

Compound 4, a percentage reported as inhibition, at one concentration (the size of the read-out at that concentration, not a potency): 92.7%
Beside the measured number, compound 4's estimate is 2.3 percentage points above it; low and high end bracket the measured number.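

In this assay, fluoro in place of hydrogen on the core of compound 3 gives a number 2.8 percentage points lower from compound 3 to compound 4 (within the scatter), and setting this step beside the earlier one shows no difference between the two cores that stands clear of the scatter: the same change on two cores in this assay, a number 8.1 percentage points higher (within the scatter) from compound 1 to compound 2 and a number 2.8 percentage points lower (within the scatter) from compound 3 to compound 4, 10.9 percentage points apart, within the scatter of two such steps Neither step stands out from the scatter on its own, so the series gives no sign that this change behaves differently on one core than on the other. This does not show that the change carries over from core to core, since the fluoro does not stand at the same place in compound 2 and compound 4, and two steps that are both within the scatter can establish neither a shared effect nor a difference.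

The compounds shown leave open how the two fluoro placements would compare on a single core, and whether a clearer step would appear at a concentration where the values could separate more widely. They also leave open what a methoxy group, a nitrile or a carboxylic acid on the phenyl ring would do, and what an open-chain amine would do in place of the saturated ring that all four compounds share.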